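Hydroxy to Chloro: Little Change Expected in Cytotoxicity

The compounds below may be only part of what the source reports. "The series", "measured", "known", "first", "only" and "open" are said of these compounds alone.

Going by the values given here, compound 2 `O=C(/C=C/c1cc2ccccc2[nH]c1=O)c1ccc(O)cc1` stands highest of the two numbers measured so far: in an ADME assay on OVCAR-3 cells (Homo sapiens) for cytotoxicity, read by sulforhodamine B assay, with a stated time of 24 h (on this read-out higher numbers stand for lower toxicity in this test and lower numbers for higher toxicity in this test), compound 2 gives 35000 nM, while compound 1 `COc1ccc(C(=O)/C=C/c2cc3ccccc3[nH]c2=O)cc1` gives 29800 nM, a gap within the scatter. Compound 3 `O=C(/C=C/c1cc2ccccc2[nH]c1=O)c1ccc(Cl)cc1` differs from compound 2 by chloro in place of hydroxy on an aromatic carbon. Among the compounds with values here, no measured step covers this exchange; the only step known, a 1.2-fold higher number from compound 1 to compound 2 (0.07 log units; within the scatter), altered the group at that same place and stayed within the scatter. A step within the scatter is therefore expected, a 1.2-fold lower number from compound 2 to compound 3 (0.07 log units; within the scatter). Compound 3 is estimated at 30000 nM, within a range from 12000 nM to 80000 nM.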

Compound 3, concentration lethal to 50% of the cells: > 100000 nM
Compound 3: only a limit was reported; the forecaster's own chance of this, stated with the estimate: 10%; middle value at least 3.3-fold (0.52 log units) away from the limit.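

This place on the ring turns out to respond to the group it carries: chloro in place of hydroxy gives an at least 2.8-fold higher number from compound 2 to compound 3 (0.45 log units; beyond the scatter) in this assay and chloro in place of methoxy gives an at least 3.3-fold higher number from compound 1 to compound 3 (0.52 log units; beyond the scatter) in the same test. Hydroxy and methoxy had stayed within the scatter of each other, while chloro is the first group shown to move the number beyond it, toward lower toxicity in this test. Compound 3 carries a limit and not a number: the limit of > 100000 nM in this assay, at which 1 of the 3 values shown sits.

Going by these compounds, the true size of both steps stays open. Also open, on these data alone, is whether fluoro, an amine or a carboxylic acid at this place would follow chloro or hydroxy.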